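Amide variation on a diaryl aminothiophene series

This account rests on a few compounds, and the source may have more. Where it says the series, first, only, none or still open, it means among the compounds named here.

Measured so far:
- compound 1, `COc1ccc(CNC(=O)c2c(N)sc(-c3ccc(Cl)cc3)c2-c2ccc(Cl)cc2)cc1`: 18200 nM
- compound 2, `COC(=O)c1c(N)sc(-c2ccc(Cl)cc2)c1-c1ccc(Cl)cc1`: 5040 nM
- compound 3, `CC1CCN(C(=O)c2c(N)sc(-c3ccc(Cl)cc3)c2-c2ccc(Cl)cc2)CC1`: 1750 nM

All three share the core and differ only in the group on the carbonyl carbon. In a functional assay on A549 cells (Homo sapiens) for inhibition, read by sulforhodamine B assay, with a stated time of 72 h (on this read-out lower numbers stand for stronger inhibition and higher numbers for weaker inhibition), compound 3 gives the lowest number of the three: a 2.9-fold lower number from compound 2 to compound 3 (0.46 log units; beyond the scatter) and a 10-fold lower number from compound 1 to compound 3 (1.02 log units; beyond the scatter), both beyond the scatter. Compound 1, the one secondary amide so far, stands highest; a 3.6-fold lower number from compound 1 to compound 2 (0.56 log units; beyond the scatter).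

Compound 4, `CCCCNC(=O)c1c(N)sc(-c2ccc(Cl)cc2)c1-c1ccc(Cl)cc1`, is the next secondary amide: butylamino in place of 4-methylpiperidin-1-yl on a carbonyl carbon. Each measured step bears on it, since each is a change at this same carbonyl carbon. The two steps into compound 3 were modest and large, and both ran toward the 4-methylpiperidin-1-yl group, so leaving it is expected to cost. Butylamino brings back the one hydrogen-bond donor that compound 1 carries, though without the ring of (4-methoxybenzyl)amino, so the full step back to the level of compound 1 is not expected. A modest rise in this assay is expected for compound 4, roughly a 3.4-fold higher number from compound 3 to compound 4 (0.54 log units; beyond the scatter). The estimate for compound 4 in this assay is 6000 nM, with a range from 2000 nM to 18000 nM.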

Compound 4, half-maximal inhibitory concentration: 8170 nM
Estimate against measurement, compound 4: 1.4-fold (0.13 log units) below; the measured number falls inside the stated range.
By their numbers in this assay, from the lowest: compound 3; then compounds 2 and 4 (each within the scatter of the next); then compound 1.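

In this assay, the new compound places a simple chain amide in the gap between the two amides already known: butylamino gives up part of the level of the 4-methylpiperidin-1-yl group (a 4.7-fold higher number from compound 3 to compound 4 (0.67 log units; beyond the scatter)), yet it does better than the (4-methoxybenzyl)amino group (a 2.2-fold lower number from compound 1 to compound 4 (0.35 log units; beyond the scatter)), so a secondary amide at this carbonyl carbon is not tied to the number of compound 1, and its outer group matters. Butylamino and methoxy are not separated on this carbonyl carbon (a 1.6-fold higher number from compound 2 to compound 4 (0.21 log units; within the scatter)), so in this set the tertiary amide of compound 3 alone stands clear of the other groups, with both secondary amides and the ester of compound 2 on the higher side. Nothing available here accounts for any of these steps.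

Compound 4 changes the ring and the amide hydrogen in one move, so the two remain unseparated; a dibutylamino amide, with no ring and no amide hydrogen, or a cyclohexylamino amide, with a ring and the amide hydrogen, would pull them apart. On these data alone, whether the methyl of the 4-methylpiperidin-1-yl group contributes, and how a morpholin-4-yl ring or a carboxylic acid would read at this carbon, also stays open.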